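A few compounds are considered here, and "the series" means these few. Any claim that something is new, unique, unknown or untested is made for them only; others in the source may bear on it.

Compound 1 `O=C(Nc1cccc(-n2cc(-c3ccncc3)c(-c3cc(O)cc(Cl)c3)n2)c1)Nc1ccc(Cl)c(C(F)(F)F)c1` stands highest of the two numbers in a functional assay on Hs-578T cells (Homo sapiens) for inhibition, read by sulforhodamine B assay, with a stated time of 48 h, tested at 1 uM; a higher number here means a weaker effect of the compound at the concentration tested, a lower number a stronger effect: in this assay compound 1 gives 87%, while compound 2 `O=C(Nc1cccc(-n2cc(-c3ccncc3)c(-c3cc(O)cc(Cl)c3)n2)c1)Nc1ccc(Cl)c(Cl)c1` gives 57%, a step of a number 30 percentage points lower from compound 1 to compound 2 (beyond the scatter). Compound 3 `COc1cc(Cl)cc(-c2nn(-c3cccc(NC(=O)Nc4ccc(Cl)c(C(F)(F)F)c4)c3)cc2-c2ccncc2)c1` differs from compound 1 in one place: methyl in place of hydrogen on an oxygen on an aromatic ring. Among the compounds with values here, no measured step alters this oxygen; the only known step changes a different group on the other side of the molecule, so it gives no guide. With nothing to point either way, compound 3 is expected to show a number 2 percentage points lower from compound 1 to compound 3 (within the scatter). The estimate for compound 3 is 85%, within 55% to 100%.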

Compound 3, a percentage reported as activity, at one concentration (the size of the read-out at that concentration, not a potency): 89%
The estimate for compound 3 lay 4 percentage points below the measured number; low and high end bracket the measured number.
By their numbers in this assay, from the lowest: compound 2; then compounds 1 and 3 (each within the scatter of the next).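

Replacing hydroxy with methoxy gives, in this assay, a number 2 percentage points higher from compound 1 to compound 3 (within the scatter). So at this oxygen, methyl in place of hydrogen produces no shift that can be told from scatter, unlike the chloro change on the other side of the molecule, which gives a number 30 percentage points lower from compound 1 to compound 2 (beyond the scatter). No measurement on hand explains this lack of a shift. Still open, from the compounds shown here alone, is whether a longer chain such as ethoxy, or an amine in place of hydroxy, would also leave the number unmoved. Also open, going by these compounds, is whether methoxy would behave the same alongside the chloro of compound 2.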